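Cytotoxicity limits across the series and one open compound

The source may report more compounds than this note shows. Statements on the series, on what has been measured and on what is new or still open speak of the compounds shown alone.

Compound 1 `C=C[C@@](C)(/C=C/c1ccc(O)cc1)CC/C=C/C(=O)OCC`, compound 2 `C=C[C@@](C)(/C=C/c1ccc(O)cc1)CC/C=C/C#N` and compound 3 `C=C[C@@](C)(/C=C/c1ccc(O)c(/C=C/C#N)c1)CCC=C(C)C` have been run in an ADME assay on HEK293 cells (Homo sapiens) for cytotoxicity, with a stated time of 72 h; on this read-out higher numbers stand for an effect only at larger amounts of compound and lower numbers for an effect already at smaller amounts. In this assay compound 1 gives > 36600 nM, which is a limit of the assay rather than a number. Compound 2 likewise stops at the limit > 36600 nM. Compound 3 also reaches only the limit > 36600 nM. The change from compound 2 to compound 1 is ethoxycarbonyl in place of cyano on a double-bonded chain carbon bound to a double-bonded chain carbon; the step it made is a step that the two limits leave unreadable from compound 2 to compound 1. The difference between the cores of compound 2 and compound 3 is not broken down here.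

Compound 4 `C=C[C@@](C)(/C=C/c1ccc(O)c(/C=C/C(=O)OCC)c1)CCC=C(C)C` has not yet been measured. It differs from compound 3 by ethoxycarbonyl in place of cyano on a double-bonded chain carbon bound to a double-bonded chain carbon, the same change in the same place as that from compound 2 to compound 1. Since all three values sit at the limit of > 36600 nM in this assay, at which 3 of the 3 values shown sit, the measured step gives no direction to carry over. The step from compound 3 to compound 4 is therefore expected to be a step that the limit leaves unreadable from compound 3 to compound 4, resting on (the limit of > 36600 nM in this assay, at which 3 of the 3 values shown sit). Compound 4 is expected to give about 50000 nM, within 30000 nM to 120000 nM, most probably again only as a limit.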

Compound 4, half-maximal effective concentration: > 36600 nM
Compound 4 ended at the assay's limit (the forecaster's own chance of this, stated with the estimate: 85%); the middle value lies beyond the limit too.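

In this assay compound 3 and compound 4 both end at a limit rather than a number, so no step can be read between them: the limit of > 36600 nM in this assay, at which 4 of the 4 values shown sit.

The compounds shown leave open at what concentration any of them affects these cells, and whether ethoxycarbonyl in place of cyano changes that concentration on either core.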